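The compounds below may be only part of what the source reports. "The series", "measured", "known", "first", "only" and "open" are said of these compounds alone.

Measured in a physicochemical assay for lipophilicity, using the shake flask method; a higher number here means a more lipophilic compound, a lower number a more polar compound:
- compound 1 `C[C@H](Oc1ccc(NC(=O)CC(=O)O)c(C2CC2)c1)c1c(Cl)ccc(F)c1Cl`: 1.9
- compound 2 `C[C@H](Oc1cccc(C2CC2)c1)c1c(Cl)ccc(F)c1Cl`: 5
- compound 3 `C[C@H](Oc1ccc(/C=C/C(=O)O)c(C2CC2)c1)c1c(Cl)ccc(F)c1Cl`: 3.6

Compound 3 stands second highest of the three. Compound 4 `C[C@H](Oc1ccc(NC(=O)CC(N)=O)c(C2CC2)c1)c1c(Cl)ccc(F)c1Cl` differs from it by a single change: ((carbamoylmethyl)carbonyl)amino in place of 2-carboxyethenyl on an aromatic carbon. Two large measured steps at this place bear on it: a number 1.70 log units higher from compound 1 to compound 3 (beyond the scatter) and a number 1.40 log units lower from compound 2 to compound 3 (beyond the scatter). The entering group resembles that of compound 1 but ends in a carbamoyl rather than a carboxylic acid, and no measurement shows what that end alone does. In this assay, no step beyond the scatter is expected, and the estimate is a number 0.10 log units higher from compound 3 to compound 4 (within the scatter). For compound 4 the estimated value is 3.7, with an expected range from 3.1 to 4.3.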

Compound 4, distribution coefficient: 3.9
Beside the measured number, compound 4's estimate is 0.20 log units below it, within the range that was stated.
By their numbers in this assay, from the lowest: compound 1; then compounds 3 and 4 (each within the scatter of the next); then compound 2.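

In this assay, amino in place of hydroxy on the carbonyl carbon gives a number 2.00 log units higher from compound 1 to compound 4 (beyond the scatter) and so shows what the end of this chain alone does at this position. Set against 2-carboxyethenyl, the ((carbamoylmethyl)carbonyl)amino group gives a number 0.30 log units higher from compound 3 to compound 4 (within the scatter), whereas in place of hydrogen it gives a number 1.10 log units lower from compound 2 to compound 4 (beyond the scatter) and the group's presence still counts. Nothing measured on these compounds accounts for these steps.

From the compounds shown here alone, whether a methyl ester or a plain acetylamino group at this place would read closer to compound 1 or compound 4 stays open. So does whether amino in place of hydroxy would give a similar step on the 2-carboxyethenyl group of compound 3.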